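Methoxycarbonyl in place of the amine side chain

This account rests on a few compounds, and the source may have more. Where it says the series, first, only, none or still open, it means among the compounds named here.

In a functional assay on SK-BR-3 cells (Homo sapiens) for cytotoxicity, read by MTT assay, with a stated time of 72 h (on this read-out lower numbers stand for stronger inhibition and higher numbers for weaker inhibition), compound 1 (`CN(C)CCCNc1c(C(=O)NCc2ccc(F)cc2)nc(Br)c2cccnc12`) gives 1000 nM and compound 2 (`CNCCCNc1c(C(=O)NCc2ccc(F)cc2)nc(Br)c2cccnc12`) stands level with it at 1000 nM on the digits shown. Compound 3 (`COC(=O)CNc1c(C(=O)NCc2ccc(F)cc2)nc(Br)c2cccnc12`) carries methoxycarbonyl in place of 2-(methylamino)ethyl on a saturated chain carbon bound to a nitrogen on an aromatic ring. Going by the values given here, the only measured step (no change at the digits printed from compound 1 to compound 2 (within the scatter)) concerns a methyl on an amine nitrogen and bears on this change only weakly. Among the compounds with values here, no measured compound lacks the amine chain. A move toward weaker inhibition in this assay is expected, of uncertain size (estimated: a 3.0-fold higher number from compound 2 to compound 3 (0.48 log units; beyond the scatter)). Compound 3 is estimated at 3000 nM with a range from 800 nM to 10000 nM for now.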

Compound 3, half-maximal inhibitory concentration: 1000 nM
Estimate against measurement, compound 3: 3.0-fold (0.48 log units) above; the measured number falls inside the stated range.
By their numbers in this assay, from the lowest: compounds 1, 2 and 3 (each within the scatter of the next).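

Methoxycarbonyl in place of 2-(methylamino)ethyl gives no change at the digits printed from compound 2 to compound 3 (within the scatter) in this assay, and methoxycarbonyl in place of 2-(dimethylamino)ethyl gives no change at the digits printed from compound 1 to compound 3 (within the scatter) on the same read-out. At this place on the chain, then, the amine nitrogen is not required to hold the level seen with compound 1 and compound 2, and an ester serves equally in these three compounds. Nothing available bears on the reason for this result. Still open, as far as these compounds go, is whether a carboxylic acid or a primary amide at this place holds the same level. From the compounds shown here alone, a longer chain or a ring-bearing chain also remains untested against these three compounds.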